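A second bromo on compound 2

The compounds below may be only part of what the source reports. "The series", "measured", "known", "first", "only" and "open" are said of these compounds alone.

Measured in a functional assay on HepG2 cells (Homo sapiens) for cytotoxicity, read by MTT assay, with a stated time of 72 h; a higher number here means a weaker inhibitor, a lower number a stronger inhibitor:
compound 1 `COc1cc2ncnc(Nc3ccc(F)c(Cl)c3)c2cc1NC(=O)N/N=C/c1ccc(OC)c(OC)c1OC`: 31200 nM
compound 2 `COc1cc2ncnc(Nc3ccc(F)c(Cl)c3)c2cc1NC(=O)N/N=C/c1ccc(O)c(Br)c1`: 23800 nM

Compound 2 has one measured neighbour, compound 1, and the two values lie within the scatter of each other. Compound 3 `COc1cc2ncnc(Nc3ccc(F)c(Cl)c3)c2cc1NC(=O)N/N=C/c1cc(Br)c(O)c(Br)c1` differs from compound 2 as 3,5-dibromo-4-hydroxyphenyl does from 3-bromo-4-hydroxyphenyl: bromo in place of hydrogen on an aromatic carbon. Within the data shown here, only one measured step bears on this, a 1.3-fold lower number from compound 1 to compound 2 (0.12 log units; within the scatter), and it adds no bromo, so it is weak guidance. No step beyond the scatter is expected in this assay, and the expected step is a 1.2-fold lower number from compound 2 to compound 3 (0.08 log units; within the scatter). Compound 3 is estimated at 20000 nM, with an expected range of 8000 nM to 50000 nM.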

Compound 3, half-maximal inhibitory concentration: 36800 nM
Estimate against measurement, compound 3: 1.8-fold (0.26 log units) below; the measured number falls inside the stated range.
By their numbers in this assay, from the lowest: compounds 2, 1 and 3 (each within the scatter of the next).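

In this assay, a second bromo ortho to the hydroxy group gives no step beyond the scatter (a 1.5-fold higher number from compound 2 to compound 3 (0.19 log units; within the scatter)), so this position tolerates the added bromo in this read-out. The 3,5-dibromo-4-hydroxyphenyl group also stays within the scatter of 2,3,4-trimethoxyphenyl (a 1.2-fold higher number from compound 1 to compound 3 (0.07 log units; within the scatter)), and all three aryl groups read alike here. No evidence is available that explains this result. Still open, from the compounds shown here alone, is whether an amine or a carboxylic acid in place of this bromo would give a step beyond the scatter.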